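The source may report more compounds than this note shows. Statements on the series, on what has been measured and on what is new or still open speak of the compounds shown alone.

Measured compounds:
compound 1, `COc1ccccc1C(=O)NCc1ccc(CNS(=O)(=O)c2ccccc2C)cc1`: 1000 nM
compound 2, `Cc1ccccc1S(=O)(=O)NCc1ccc(CNC(=O)c2cccnc2)cc1`: 1000 nM
compound 3, `O=C(NCc1ccc(CNS(=O)(=O)c2ccc(F)cc2)cc1)c1cccnc1`: 100 nM

In an assay on MDA-MB-231 cells for displacement of a labelled ligand from C-X-C chemokine receptor type 4 (Homo sapiens), read by fluorescence and microscopy, with stated times of 10 min and 30 min (a higher number here means that more compound is needed for the effect, a lower number that less compound is needed), compound 1 gives 1000 nM, level with compound 2 at the digits printed; the two share the highest number of the three, while compound 3 sits at 100 nM. Exchange at the carbonyl carbon, no change at the digits printed from compound 1 to compound 2 (within the scatter), leaves the number where it was. Exchange at the sulfonyl sulfur, a 10-fold lower number from compound 2 to compound 3 (1.00 log units; beyond the scatter), is the only step in the series that moves the number, and it is modest.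

Compound 4, `COc1ccccc1C(=O)NCc1ccc(CNS(=O)(=O)c2cccc(C)c2)cc1`, differs from compound 1 by 3-methylphenyl in place of 2-methylphenyl on a sulfonyl sulfur. Within the data shown here, the one measured step on the sulfonyl sulfur removed the 2-methylphenyl group entirely rather than relocating its methyl, so it bears on this change only loosely; no measured pair tests a 3-methylphenyl group. Among the measured compounds shown here, a step in the same direction as the one from compound 2 to compound 3 is expected, but smaller and possibly within the scatter.

Compound 4 is estimated at 500 nM in this assay, with a range of 150 nM to 1500 nM, corresponding to an expected step of a 2.0-fold lower number from compound 1 to compound 4 (0.30 log units; within the scatter).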

Compound 4, effective concentration (reported as EC, without a stated level of effect): 1000 nM
The estimate for compound 4 lay 2.0-fold (0.30 log units) below the measured number; the measured number falls inside the stated range.
By their numbers in this assay, from the lowest: compound 3; then compounds 1, 2 and 4 (each within the scatter of the next).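

In this assay, moving the methyl group on the sulfonyl sulfur's aryl ring gives no change at the digits printed from compound 1 to compound 4 (within the scatter) and so does not separate 3-methylphenyl from 2-methylphenyl with the 2-methoxyphenyl group on the carbonyl carbon. This exchange at the sulfonyl sulfur keeps the same atoms, whereas the exchange for 4-fluorophenyl that gave a 10-fold lower number from compound 2 to compound 3 (1.00 log units; beyond the scatter) changed the substituent itself and was read with pyridin-3-yl on the carbonyl carbon. No measurement at hand accounts for the result.

On these data alone, it remains open whether 4-fluorophenyl would give a similar step with 2-methoxyphenyl on the carbonyl carbon, so the two sides of the molecule cannot yet be treated as independent. Also open, as far as these compounds go, is how 4-methylphenyl, 4-aminophenyl or 4-carboxyphenyl would read on the sulfonyl sulfur.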